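Aryl variation at the branching carbon of the carbamate series

A few compounds are considered here, and "the series" means these few. Any claim that something is new, unique, unknown or untested is made for them only; others in the source may bear on it.

Measured so far:
compound 1 `O=C(Nc1cccc(Cl)c1)O/N=C(\C1CCCCC1)C(Cc1ccncc1)C1CCCCC1` — 117 nM
compound 2 `O=C(Nc1cccc(Cl)c1)O/N=C(\C1CCCCC1)C(Cc1ccccn1)C1CCCCC1` — 40.4 nM
compound 3 `O=C(Nc1cccc(Cl)c1)O/N=C(\C1CCCCC1)C(Cc1ccccc1)C1CCCCC1` — 16 nM

In an assay on isolated protein for displacement of a labelled ligand from metabotropic glutamate receptor 5 (Rattus norvegicus) (on this read-out lower numbers stand for stronger inhibition and higher numbers for weaker inhibition), compound 3 stands lowest of the three numbers and is the strongest inhibitor of the set. Its nearest neighbour is compound 2 a 2.5-fold lower number from compound 2 to compound 3 (0.40 log units; beyond the scatter), the furthest is compound 1 a 7.3-fold lower number from compound 1 to compound 3 (0.86 log units; beyond the scatter); the remaining step of a 2.9-fold lower number from compound 1 to compound 2 (0.46 log units; beyond the scatter) is of similar modest size.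

Compound 4 `CN(C)c1ccc(CC(/C(=N/OC(=O)Nc2cccc(Cl)c2)C2CCCCC2)C2CCCCC2)cc1` differs from compound 3 by dimethylamino in place of hydrogen on an aromatic carbon.

Within the data shown here, no measured step bears directly on this change: each of the three steps exchanges one aromatic ring for another at the branching carbon, whereas here the phenyl ring of compound 3 is kept and a substituent is added to it. Among the measured compounds shown here, the series therefore gives no direction for the step. The expected outcome for compound 4 in this assay is a step from compound 3 a 1.3-fold higher number from compound 3 to compound 4 (0.10 log units; within the scatter) that stays within the scatter, with a wide range to cover both directions. Compound 4 is estimated at 20 nM, between 6 nM and 70 nM.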

Compound 4, inhibition constant: > 1000 nM
Compound 4 gave a limit, no number; the forecaster's own chance of this, stated with the estimate: 2%; middle value at least 50-fold (1.69 log units) from the limit.
By their numbers in this assay, from the lowest: compound 3; then compound 2; then compound 1. At a limit, above all of these: compound 4.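

In this assay compound 4 is recorded only as a limit of the assay, not as a number: the limit of > 1000 nM in this assay, at which 1 of the 4 values shown sits.

Dimethylamino in place of hydrogen on the phenyl ring, para to a large group, gives a larger step than any exchange of one ring for another in the series: an at least 62-fold higher number from compound 3 to compound 4 (1.79 log units; beyond the scatter). The 4-(dimethylamino)phenyl group also falls behind both pyridinyl groups, an at least 24-fold higher number from compound 2 to compound 4 (1.39 log units; beyond the scatter) and an at least 8.5-fold higher number from compound 1 to compound 4 (0.93 log units; beyond the scatter), so this position, which showed only modest steps on ring exchange, is far more sensitive to this substituent.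

From the compounds shown here alone, the full size of these steps stays open, as all three rest on a limit. Also open, going by these compounds, is whether the loss is specific to dimethylamino or extends to other groups at the same place, such as methoxy, methyl or fluorine.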